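Pyrrolidin-2-yl in place of 1-(methylamino)ethyl

This account rests on a few compounds, and the source may have more. Where it says the series, first, only, none or still open, it means among the compounds named here.

Among the compounds with values here, in an in vivo ADME assay on the whole organism (strain Sprague-Dawley) for pharmacokinetics, with Rattus norvegicus as the target (a lower number here means that more of the compound stays in the plasma, a higher number that more of the compound sits outside the plasma), compound 1 `CN[C@@H](C)c1ccc(N2CC[C@H](NS(=O)(=O)c3ccc4cc(Cl)ccc4c3)C2=O)c(F)c1` gives 2.4 L/kg, the higher of the two numbers so far. Compound 2 `O=C1[C@@H](NS(=O)(=O)c2ccc3c(Cl)c[nH]c3c2)CCN1c1ccc(C2CCCN2)cc1F` gives 0.8 L/kg, lower by more than the scatter. Compound 3 `O=C1[C@@H](NS(=O)(=O)c2ccc3cc(Cl)ccc3c2)CCN1c1ccc([C@@H]2CCCN2)cc1F` carries pyrrolidin-2-yl in place of 1-(methylamino)ethyl on an aromatic carbon, meta to a fluoro group: pyrrolidin-2-yl in place of 1-(methylamino)ethyl on an aromatic carbon. Within the data shown here, no measured pair isolates this change, so the expectation in this assay rests on the structural change alone, with no step beyond the scatter and no firm direction. The expected step is a 1.2-fold lower number from compound 1 to compound 3 (0.08 log units; within the scatter). For compound 3 the estimated value is 2 L/kg, with an expected range of 1 L/kg to 3.8 L/kg.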

Compound 3, volume of distribution at steady state: 1.7 L/kg
For compound 3 the middle estimate is 1.2-fold (0.07 log units) above the measured one; low and high end bracket the measured number.
By their numbers in this assay, from the lowest: compound 2; then compounds 3 and 1 (each within the scatter of the next).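

In this assay, pyrrolidin-2-yl in place of 1-(methylamino)ethyl on this aromatic carbon, para to a large group, gives a 1.4-fold lower number from compound 1 to compound 3 (0.15 log units; within the scatter). This first matched pair shows that the change from an open chain to a five-membered ring on this carbon produces no step beyond the scatter. No available evidence explains this result.

The compounds shown leave open whether a larger ring amine such as piperidin-2-yl, or a carboxylic acid on this carbon, would give a step beyond the scatter. They also leave open how the opposite stereocentre of pyrrolidin-2-yl would read in this assay.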